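The source may hold more compounds than are shown below. What is called first, only, known or untested is meant among the compounds shown, and "the series" means these compounds.

Compound 1 `CCc1cc(-c2nn(C(C)C)c3ncnc(N)c23)no1` stands lowest of the two numbers measured in an assay on isolated protein for inhibition of proto-oncogene tyrosine-protein kinase receptor Ret (Homo sapiens), read by radiometric assay and 33P incorporation, in the presence of a further agent that is not named here; a lower number here means a stronger inhibitor, a higher number a weaker inhibitor: compound 1 gives 41 nM. Among the compounds with values here, compound 2 `CC(C)n1nc(/C=N/OCc2ccccc2)c2c(N)ncnc21`, the only other measured compound, gives 8330 nM in this assay, a gap beyond the scatter, so compound 1 is clearly the stronger of the two. Within the data shown here, no pair of measured compounds differs in a single place, so no measured step of this kind is available. Compound 3 `CC(C)c1cc(-c2nn(C(C)C)c3ncnc(N)c23)no1` differs from compound 1 by methyl in place of hydrogen on a saturated chain carbon bound to an aromatic carbon and a saturated chain carbon. With only the two values of compound 1 and compound 2 to draw on, the estimated step of a 1.0-fold lower number from compound 1 to compound 3 (0.01 log units; within the scatter) is expected to be small, in either direction, and likely within the usual scatter. Compound 3 is therefore estimated at 40 nM in this assay, with a range from 15 nM to 120 nM.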

Compound 3, half-maximal inhibitory concentration: 41 nM
Compound 3: middle estimate off by 1.0-fold (0.01 log units), on the low side, and the stated range covers the measured number.
By their numbers in this assay, from the lowest: compounds 1 and 3 (each within the scatter of the next); then compound 2.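

Ethyl to isopropyl, that is methyl in place of hydrogen on a saturated chain carbon bound to an aromatic carbon and a saturated chain carbon, gives the first single-place step in this series: in this assay it shows no change at the digits printed from compound 1 to compound 3 (within the scatter). This position therefore takes one added methyl with no change beyond the scatter, something the earlier pair, which differs in more than one place, could not show. Nothing measured here bears on why the number holds, so no reason can be given.

The compounds shown leave open whether tert-butyl, cyclopropyl or a longer chain such as n-butyl at this place would hold the number in this assay as well. They also leave open what an amine or a carboxylic acid on that chain carbon would do.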